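This account rests on a few compounds, and the source may have more. Where it says the series, first, only, none or still open, it means among the compounds named here.

Compound 1 `Cn1cc(C2CC(c3ccc(Br)cc3)=NN2C(=O)c2cccnc2)c2cc(Br)ccc21` is measured in a functional assay on A549 cells (Homo sapiens) for inhibition, read by MTT assay, with a stated time of 48 h; a lower number here means a stronger inhibitor of growth, a higher number a weaker inhibitor of growth. In this assay compound 1 gives > 10000 nM, a limit of the assay and not a number. Among the compounds with values here, compound 2 `COc1ccc(C2=NN(C(=O)c3cccnc3)C(c3cn(C)c4ccc(Br)cc34)C2)cc1` is its partner in the one counted change, (methoxy in place of bromo on an aromatic carbon), and in this assay compound 2 gives 1190 nM; the resulting step is an at least 8.4-fold lower number from compound 1 to compound 2 (0.92 log units; beyond the scatter). Compound 3 `COc1ccc2c(c1)c(C1CC(c3ccc(Br)cc3)=NN1C(=O)c1ccc(OC)nc1)cn2C` carries a different core; how that core differs from the core of compound 1 is not broken down here. In this assay compound 3 gives > 10000 nM, again a limit of the assay. Compound 4 `COc1ccc(C2=NN(C(=O)c3ccc(OC)nc3)C(c3cn(C)c4ccc(OC)cc34)C2)cc1` is not yet measured and differs from compound 3 by the same change, (methoxy in place of bromo on an aromatic carbon). The step from compound 3 to compound 4 is expected to be an at least 3.3-fold lower number from compound 3 to compound 4 (0.52 log units; beyond the scatter), resting on the step of an at least 8.4-fold lower number from compound 1 to compound 2 (0.92 log units; beyond the scatter), with the reservation that compound 3 sits at the limit of > 10000 nM in this assay, at which 2 of the 3 values shown sit. Compound 4 is therefore estimated at 3000 nM, within 700 nM to 15000 nM.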

Compound 4, concentration for 50% growth inhibition: 450 nM
Compound 4: the middle estimate sits 6.7-fold (0.82 log units) above what was measured, and the stated range ends above it.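

Methoxy in place of bromo, read one bond further out as 4-bromophenyl to 4-methoxyphenyl, moves the number the same way on both cores shown, and in this assay the new step is an at least 22-fold lower number from compound 3 to compound 4 (1.34 log units; beyond the scatter) on the core of compound 3. Compound 3 gives > 10000 nM and this is a limit of the assay, not a number. The direction therefore carries from one core to the other, but the size of the step on either core stays unfixed, and the two sizes cannot be compared: the same change on two cores in this assay, an at least 8.4-fold lower number (0.92 log units; beyond the scatter) from compound 1 to compound 2 and an at least 22-fold lower number (1.34 log units; beyond the scatter) from compound 3 to compound 4; the limit leaves it open whether they differ.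

Only two cores are shown, so whether the change holds on any other core remains open. Also open, from the compounds shown here alone, is how an amine or a longer chain in place of the methoxy on the 4-methoxyphenyl group would read in this assay.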